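The compounds below may be only part of what the source reports. "The series", "measured", "known", "first", "only" and "open" are said of these compounds alone.

Three compounds of the series have numbers in a functional assay on SNU-638 cells (Homo sapiens) for cytotoxicity, read by sulforhodamine B assay, with a stated time of 72 h (on this read-out higher numbers stand for weaker inhibition and lower numbers for stronger inhibition), so far. Compound 1 `CCS(=O)(=O)Nc1cc(-c2ccc3ncnc(Nc4ccc(F)cc4F)c3c2)cnc1OC` gives 2050 nM in this assay. Compound 2 `CCS(=O)(=O)Nc1cc(-c2ccc3ncnc(Nc4ccc(OC)cc4)c3c2)cnc1OC` gives 3970 nM in this assay. Compound 3 `COC(=O)c1cccc(Nc2ncnc3ccc(-c4cnc(OC)c(NS(=O)(=O)c5ccc(F)cc5F)c4)cc23)c1` gives 400 nM in this assay. Among the measured compounds shown here, compound 2 therefore stands highest of the three numbers: the nearest is compound 1, separated by a 1.9-fold higher number from compound 1 to compound 2 (0.29 log units; within the scatter), and the furthest is compound 3, whose value sits well apart from that of compound 2 beyond the scatter, though the two differ in more than one place and no single step joins them.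

Compound 4 `CCS(=O)(=O)Nc1cc(-c2ccc3ncnc(Nc4ccc(F)nc4)c3c2)cnc1OC` carries the change (6-fluoropyridin-3-yl in place of 4-methoxyphenyl on a nitrogen on an aromatic ring). For the measured compounds named here, the only measured step at the same place is the one from compound 1 to compound 2, which swapped the aryl on that nitrogen and stayed within the scatter. On that basis no step beyond the scatter is expected from compound 2 to compound 4, the expected step being a 1.4-fold lower number from compound 2 to compound 4 (0.15 log units; within the scatter). For compound 4 the estimate in this assay is 2800 nM, expected to lie between 900 nM and 8000 nM.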

Compound 4, half-maximal inhibitory concentration: 6520 nM
The estimate for compound 4 lay 2.3-fold (0.37 log units) below the measured number, within the range that was stated.
By their numbers in this assay, from the lowest: compound 3; then compounds 1, 2 and 4 (each within the scatter of the next, the first and the last beyond it).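

In this assay, putting 6-fluoropyridin-3-yl in place of 4-methoxyphenyl gives a 1.6-fold higher number from compound 2 to compound 4 (0.22 log units; within the scatter), so this change of aryl on the nitrogen does not separate the two compounds. Among the compounds shown here, putting the same group in place of 2,4-difluorophenyl gives a 3.2-fold higher number from compound 1 to compound 4 (0.50 log units; beyond the scatter), the first step at this position to pass the scatter, though it is modest, so the position does respond to the choice of aryl within this small set. Nothing measured bears on the reason for either step.

From the compounds shown here alone, only these three aryl groups have been compared at this position on an otherwise unchanged core, so it remains open whether a non-aromatic group such as a morpholine ring or a longer alkyl chain would be tolerated there. Also open, going by these compounds, is how a carboxylic acid or a primary amine on the aryl ring would read in this assay.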